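The source may hold more compounds than are shown below. What is called first, only, known or untested is meant among the compounds shown, and "the series" means these compounds.

Measured compounds:
- compound 1 `N#CC1=C(N)Oc2c(c3nc4ccccc4nc3c3ccccc23)C12C(=O)N(Cc1cnnn1-c1cccc(Br)c1)c1ccccc12`: in a functional assay on MCF7 cells (Homo sapiens) for antiproliferative activity, read by MTT assay, with a stated time of 48 h (a higher number here means a weaker inhibitor, a lower number a stronger inhibitor), compound 1 gives > 50000 nM, which is a limit of the assay rather than a number.
- compound 2 `Cc1ccc(C)c(-n2nncc2CN2C(=O)C3(C(C#N)=C(N)Oc4c3c3nc5ccccc5nc3c3ccccc43)c3ccccc32)c1`: compound 2 gives > 50000 nM in this assay, also a limit.
- compound 3 `N#CC1=C(N)Oc2c(N)cc3nc4ccccc4nc3c2C12C(=O)N(Cc1cnnn1-c1ccccc1Cl)c1ccccc12`: compound 3 gives 34400 nM in this assay.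

For the measured compounds named here, compound 3 thus supplies the only actual number; the two other compounds sit at the limit of > 50000 nM in this assay, at which 2 of the 3 values shown sit, so no ordering can be drawn between them and compound 3 beyond what the three values show. The change from compound 1 to compound 2 a step that the two limits leave unreadable from compound 1 to compound 2 cannot be sized, because both compounds rest at the limit of > 50000 nM in this assay, at which 2 of the 3 values shown sit.

Compound 4 `COc1ccc(-n2nncc2CN2C(=O)C3(C(C#N)=C(N)Oc4c(N)cc5nc6ccccc6nc5c43)c3ccccc32)cc1` is the next compound. It differs from compound 3 in one place: 4-methoxyphenyl in place of 2-chlorophenyl on an aromatic nitrogen. Going by the values given here, the only change of this kind that has been measured, the one from compound 1 to compound 2, is unreadable, so no size or direction can be taken from it. Without evidence of an effect, the change from compound 3 to compound 4 is expected to stay within the scatter, giving an estimated step of a 1.0-fold higher number from compound 3 to compound 4 (0.01 log units; within the scatter). Compound 4 is therefore estimated at 35000 nM in this assay, with a likely range from 14000 nM to 80000 nM.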

Compound 4, half-maximal inhibitory concentration: > 50000 nM
Compound 4: no number, only a limit; the forecaster's own chance of this, stated with the estimate: 40%; middle value at least 1.4-fold (0.15 log units) from the limit.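

In this assay, for the compounds shown here, putting 4-methoxyphenyl in place of 2-chlorophenyl on the aromatic nitrogen gives the first readable step at this position: an at least 1.4-fold higher number from compound 3 to compound 4 (0.16 log units; that floor lies within the scatter). The value of compound 4 is a limit and not a number, so the step has only a floor for its size, and that floor does not establish a real loss of activity. Compound 3 therefore remains the only compound with an actual number, while the rest of the series sits at one limit: the limit of > 50000 nM in this assay, at which 3 of the 4 values shown sit.

The compounds shown leave open how an unsubstituted phenyl or a 4-chlorophenyl would read at this position, which would help separate the kind of substituent from its place on the ring. Also open, as far as these compounds go, is whether an amine or a carboxylic acid on that ring would give a clearly lower number than compound 3.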